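The source may hold more compounds than are shown below. What is called first, only, known or untested is meant among the compounds shown, and "the series" means these compounds.

Measured so far in a functional assay on HeLa cells (Homo sapiens) for cytotoxicity, read by WST assay, with a stated time of 48 h; a higher number here means a weaker inhibitor, a lower number a stronger inhibitor:
compound 1 `COc1cc(C(c2ccc(O)c(OC)c2)[C@@H](C)[C@@H](C)CO)ccc1O`: > 100000 nM
compound 2 `COc1cc(C(c2ccc(O)c(OC)c2)[C@@H](C)[C@@H](C)CF)ccc1O`: 42000 nM
compound 3 `COc1cc(C(c2ccc(O)c(OC)c2)[C@@H](CO)C(C)C)ccc1O`: > 100000 nM

Compound 3 stands at > 100000 nM, which is a limit and not a number. Compound 1 gives > 100000 nM, which is also a limit. Together they make up (the limit of > 100000 nM in this assay, at which 2 of the 3 values shown sit). Only compound 2 has a numerical value, 42000 nM.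

The next compound is compound 4 `COc1cc(C(c2ccc(O)c(OC)c2)[C@H](CF)C(C)C)ccc1O`. The change is 1-(fluoromethyl)-2-methylpropyl in place of 1-(hydroxymethyl)-2-methylpropyl on a saturated chain carbon bound to two aromatic carbons.

Going by the values given here, the closest precedent is an at least 2.3-fold lower number from compound 1 to compound 2 (0.37 log units; beyond the scatter), where fluoro replaces hydroxy on a saturated chain carbon of the other chain. The step that the two limits leave unreadable from compound 1 to compound 3 gives no size for the chain change. The step of an at least 2.3-fold higher number from compound 2 to compound 3 (0.37 log units; beyond the scatter) combines the chain change with the end-group change, so it adds no separate measure of the fluoro exchange.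

On this single pair, a lower number is expected for compound 4 in this assay, although a result at the limit remains possible. The estimated change is an at least 2.2-fold lower number from compound 3 to compound 4 (0.34 log units; beyond the scatter). The estimate for compound 4 is 45000 nM, with an expected range of 18000 nM to 100000 nM.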

Compound 4, half-maximal inhibitory concentration: 19000 nM
Estimate against measurement, compound 4: 2.4-fold (0.37 log units) above, within the range that was stated.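

In this assay, fluoro in place of hydroxy now gives a lower number on the second chain as well: 1-(fluoromethyl)-2-methylpropyl in place of 1-(hydroxymethyl)-2-methylpropyl gives an at least 5.2-fold lower number from compound 3 to compound 4 (0.72 log units; beyond the scatter), in the same direction as an at least 2.3-fold lower number from compound 1 to compound 2 (0.37 log units; beyond the scatter) on the first chain. Going by these compounds alone, with compound 2 and compound 4 both giving numerical values, the chain change can be read for the first time, as a 2.2-fold lower number from compound 2 to compound 4 (0.34 log units; beyond the scatter), which favours 1-(fluoromethyl)-2-methylpropyl over 2-(fluoromethyl)-1-methylpropyl on a saturated chain carbon bound to two aromatic carbons. The step that changes both chain and end group, an at least 5.2-fold lower number from compound 1 to compound 4 (0.72 log units; beyond the scatter), and the step to compound 4 from its hydroxy partner give only lower bounds on size, because compound 1 and compound 3 each stand at a limit: the limit of > 100000 nM in this assay, at which 2 of the 4 values shown sit.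

The two exchanges cannot separate a gain from the entering fluoro from a gain from the loss of the hydroxy, and a methoxy, chloro or amine end group would bear on that question. From the compounds shown here alone, how a longer chain carrying the fluoro end group would read in this assay also stays open.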